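Aryl substituent change from chloro to vinyl in compound 4

This account rests on a few compounds, and the source may have more. Where it says the series, first, only, none or still open, it means among the compounds named here.

The series shares one core carrying a substituted phenyl ring. Compound 1 `C/C(=C\c1cc(-c2ccc(C)cc2)cs1)C(N)=O` bears a methyl on that ring. In a functional assay on MCF7 cells (Homo sapiens) for cytotoxicity, read by CCK-8 assay, with a stated time of 24 h (a higher number here means a weaker inhibitor, a lower number a stronger inhibitor), compound 1 gives only a limit, > 50000 nM, with no number. Compound 2 `C/C(=C\c1cc(-c2ccc(C#N)cc2)cs1)C(N)=O` carries a cyano there and in this assay compound 2 gives 240 nM. Compound 3 `C/C(=C\c1cc(-c2ccc(Cl)cc2)cs1)C(N)=O` carries a chloro and in this assay compound 3 gives 17100 nM, the highest of the two numbers shown, the nearest being compound 2, from which the step of a 71-fold higher number from compound 2 to compound 3 (1.85 log units; beyond the scatter). The other steps are an at least 200-fold lower number from compound 1 to compound 2 (2.31 log units; beyond the scatter) and an at least 2.9-fold lower number from compound 1 to compound 3 (0.46 log units; beyond the scatter).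

Compound 4 `C=Cc1ccc(-c2csc(/C=C(\C)C(N)=O)c2)cc1` differs from compound 3 by vinyl in place of chloro on an aromatic carbon. Going by the values given here, no measured step involves a vinyl, so the bearing steps are only those at the same position: the change from methyl to chloro was modest, the change from methyl or chloro to cyano was large. A vinyl is neither of these; a step of moderate size in this assay, most likely toward a lower number, is expected, well short of the effect of cyano. For compound 4 the estimate in this assay is 8000 nM, within 1500 nM to 40000 nM. The expected step is thus a 2.1-fold lower number from compound 3 to compound 4 (0.33 log units; beyond the scatter).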

Compound 4, half-maximal inhibitory concentration: > 50000 nM
Compound 4: only a limit was reported; the forecaster's own chance of this, stated with the estimate: 10%; middle value at least 6.2-fold (0.79 log units) away from the limit.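

In this assay, vinyl in place of chloro gives an at least 2.9-fold higher number from compound 3 to compound 4 (0.46 log units; beyond the scatter), and vinyl in place of cyano gives an at least 200-fold higher number from compound 2 to compound 4 (2.31 log units; beyond the scatter), so at this position, para to a large group, the vinyl keeps neither the number of compound 3 nor that of compound 2. Compound 4 reports only a limit, > 50000 nM, and this shows that a change of one small group here can take the series from a measurable number to a limit, even when the entering group, like the cyano, contains a multiple bond. The step between compound 1 and compound 4 cannot be read, so methyl and vinyl cannot be ranked against each other, and among the four compounds only chloro and cyano give numbers: the limit of > 50000 nM in this assay, at which 2 of the 4 values shown sit.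

From the compounds shown here alone, it remains open whether the low number of compound 2 is particular to the nitrile or extends to other groups at this position, such as a carboxylic acid, an amine, a methoxy group or a longer chain. Going by these compounds, how far compound 1 and compound 4 lie past their limits also stays unknown, as does whether the order of compound 2 and compound 3 holds in other cells.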